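Trifluoromethyl in Place of Bromo: Expectation for Compound 4

The source may hold more compounds than are shown below. What is called first, only, known or untested is meant among the compounds shown, and "the series" means these compounds.

Measured so far:
compound 1 `Cc1ccc(-c2nn(-c3ccccc3)cc2-c2nc3ccccc3n2S(=O)(=O)c2ccc(Br)cc2)cc1` gives 3160 nM
compound 2 `Cc1ccc(-c2nn(-c3ccccc3)cc2-c2nc3ccccc3n2S(=O)(=O)c2ccc(C(F)(F)F)cc2)cc1` gives 2340 nM
compound 3 `O=S(=O)(c1ccc(Br)cc1)n1c(-c2cn(-c3ccccc3)nc2-c2ccc(C(F)(F)F)cc2)nc2ccccc21` gives 2470 nM

All three numbers come from a functional assay on MCF7 cells (Homo sapiens) for antiproliferative activity, read by MTT assay, with a stated time of 24 h; a higher number here means a weaker inhibitor, a lower number a stronger inhibitor. Compound 2 differs from compound 1 by trifluoromethyl in place of bromo on an aromatic carbon, and this gave a 1.4-fold lower number from compound 1 to compound 2 (0.13 log units; within the scatter). Compound 3 differs from compound 1 in another place, by trifluoromethyl in place of methyl on an aromatic carbon, which gave a 1.3-fold lower number from compound 1 to compound 3 (0.11 log units; within the scatter). Compounds 2 and 3 differ from each other in two places, and their values lie within the scatter of each other. Among the measured compounds shown here, no step among the three compounds reaches beyond the scatter, so nothing here can be called a trend.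

Compound 4 `O=S(=O)(c1ccc(C(F)(F)F)cc1)n1c(-c2cn(-c3ccccc3)nc2-c2ccc(C(F)(F)F)cc2)nc2ccccc21` has not yet been measured. It differs from compound 3 by trifluoromethyl in place of bromo on an aromatic carbon. For the measured compounds named here, this is the same change as the one from compound 1 to compound 2: the group that leaves, the group that enters and the place are described in the same words. The two cores, that of compound 1 and that of compound 3, differ by trifluoromethyl in place of methyl on an aromatic carbon.

Because the earlier instance of this change gave a 1.4-fold lower number from compound 1 to compound 2 (0.13 log units; within the scatter), the step from compound 3 to compound 4 is expected to be of similar size, namely a 1.4-fold lower number from compound 3 to compound 4 (0.14 log units; within the scatter), which is within the scatter. Compound 4 is therefore estimated at 1800 nM in this assay, with a plausible range from 900 nM to 3600 nM. This expectation rests on a single earlier instance and on compound 3 at 2470 nM, so it is held loosely.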

Compound 4, half-maximal inhibitory concentration: 1240 nM
Estimate against measurement, compound 4: 1.5-fold (0.16 log units) above; the range from low to high includes it.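

In this assay, trifluoromethyl in place of bromo gave a 2.0-fold lower number from compound 3 to compound 4 (0.30 log units; within the scatter), and set beside its earlier instance, this step shows no difference that can be told between the two cores: the same change on two cores in this assay, a 1.4-fold lower number (0.13 log units; within the scatter) from compound 1 to compound 2 and a 2.0-fold lower number (0.30 log units; within the scatter) from compound 3 to compound 4, 1.5-fold (0.17 log units) apart, within the scatter of two such steps. Trifluoromethyl in place of methyl, read on the other pair, gave a 1.9-fold lower number from compound 2 to compound 4 (0.28 log units; within the scatter), and the comparison with its earlier instance comes out the same way: the same change on two cores in this assay, a 1.3-fold lower number (0.11 log units; within the scatter) from compound 1 to compound 3 and a 1.9-fold lower number (0.28 log units; within the scatter) from compound 2 to compound 4, 1.5-fold (0.17 log units) apart, within the scatter of two such steps. Among the compounds shown here, this shows that each change could be carried from one core to the other without a step that departs from its earlier instance, but it does not show that either change has a real effect of its own on the number; all four steps lie within the scatter, and each change is seen on only two cores.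

The compounds shown leave open what other groups, such as an amine, a carboxylic acid or a longer alkyl chain, would do in place of the bromo or methyl group on either core. They also leave open whether these two changes would read the same way in any measurement other than this assay.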